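This account rests on a few compounds, and the source may have more. Where it says the series, first, only, none or still open, it means among the compounds named here.

Of the compounds shown here, two sharing one core have been measured in a functional assay on Shh Light II cells (Mus musculus) for inhibition, read by a luciferase reporter; a higher number here means a weaker inhibitor, a lower number a stronger inhibitor: compound 1 (`O=C(NC1CC[S+]([O-])CC1)N1CCC(c2nc(-c3ccc4ccccc4n3)no2)CC1`) gives 850 nM, and compound 2 (`O=C(Nc1cccnc1Cl)N1CCC(c2nc(-c3ccc4ccccc4n3)no2)CC1`) gives 1600 nM. Going by the values given here, compound 2 therefore stands level with compound 1, since the only measured step, a 1.9-fold higher number from compound 1 to compound 2 (0.27 log units; within the scatter), does not separate them.

Compound 3 (`O=C(NC1CCCCC1)N1CCC(c2nc(-c3ccc4ccccc4n3)no2)CC1`) has not yet been measured. It differs from compound 2 by one exchange, cyclohexyl in place of 2-chloropyridin-3-yl on an amide-type nitrogen. Among the compounds with values here, the single measured step bears on this exchange, as compound 1 also has a six-membered non-aromatic ring at that place, although its ring holds a hetero atom. Leaving such a ring for the aromatic ring of compound 2 moved the number only within the scatter, so no step beyond the scatter is expected on going back to a non-aromatic ring. A small move towards the value of compound 1, 850 nM, seems the likeliest direction. The expected step is a 1.8-fold lower number from compound 2 to compound 3 (0.25 log units; within the scatter). Within the data shown here, no measured compound has a ring of carbon only at this place, so the range stays wide. Compound 3 is estimated at 900 nM, with an expected range of 300 nM to 2700 nM.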

Compound 3, half-maximal inhibitory concentration: 57 nM
Estimate against measurement, compound 3: 16-fold (1.20 log units) above, and the stated range ends above it.
By their numbers in this assay, from the lowest: compound 3; then compounds 1 and 2 (each within the scatter of the next).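

In this assay the exchange of 2-chloropyridin-3-yl for cyclohexyl on the amide-type nitrogen brought a 28-fold lower number from compound 2 to compound 3 (1.45 log units; beyond the scatter) and so showed that this position can move the number far more than the first pair suggested. A non-aromatic ring alone does not account for the result, as the ring of compound 1 is also non-aromatic, and yet the change to cyclohexyl gave a 15-fold lower number from compound 1 to compound 3 (1.17 log units; beyond the scatter) and set compound 3 apart from both other compounds. Among these three compounds, only the ring of carbon only stands apart, while the two rings with a hetero atom remain within the scatter of each other, and nothing measured here explains that difference.

The compounds shown leave open whether the carbon-only ring must be non-aromatic, which phenyl at this place would test, and whether a ring is needed at all, which cyclopentyl or an open chain such as hexyl would help to settle. They also leave open whether cyclohexyl would have the same effect on any core other than the shared one.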